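Methoxy for methyl on the chain-borne ring of compound 1

The source may hold more compounds than are shown below. What is called first, only, known or untested is meant among the compounds shown, and "the series" means these compounds.

Compound 1 `CC1=C(C)C(=O)C(CCCCCCCCCCn2cc(C[C@H](O)COCCOC[C@@H](O)Cc3ccc(-c4ccccc4)cc3)nn2)=C(C)C1=O` is the reference point of this short series. In a functional assay on SGC-7901 cells (Homo sapiens) for inhibition, read by MTT assay, with a stated time of 72 h (on this read-out lower numbers stand for stronger inhibition of growth and higher numbers for weaker inhibition of growth), compound 1 gives 350 nM, the lowest of the two numbers recorded so far. Compound 2 `O[C@H](COCCOC[C@@H](O)Cc1cn(Cc2ccc3ccccc3c2)nn1)Cc1ccc(-c2ccccc2)cc1`, a differently substituted analogue of the shared core, gives 12100 nM in this assay; the gap between compound 2 and compound 1 lies beyond the scatter, so compound 1 is the stronger growth inhibitor of the measured pair.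

Compound 3 `COC1=C(C)C(=O)C(CCCCCCCCCCn2cc(C[C@H](O)COCCOC[C@@H](O)Cc3ccc(-c4ccccc4)cc3)nn2)=C(C)C1=O` is not yet measured. It differs from compound 1 by methoxy in place of methyl on a double-bonded ring carbon. For the measured compounds named here, no measured pair shows such an exchange, so the size of this step has no direct precedent here. Given the small size of the change, the step from compound 1 to compound 3 is expected to be a 1.1-fold higher number from compound 1 to compound 3 (0.06 log units; within the scatter), a difference that is not expected to exceed the scatter in either direction. Compound 3 is therefore estimated at 400 nM in this assay, with a range from 130 nM to 1300 nM.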

Compound 3, concentration for 50% growth inhibition: 505 nM
Compound 3: middle estimate off by 1.3-fold (0.10 log units), on the low side; low and high end bracket the measured number.
By their numbers in this assay, from the lowest: compounds 1 and 3 (each within the scatter of the next); then compound 2.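

Methoxy in place of methyl on a double-bonded ring carbon gives, in this assay, a 1.4-fold higher number from compound 1 to compound 3 (0.16 log units; within the scatter) and so leaves compounds 1 and 3 indistinguishable on this read-out. For the compounds shown here, this is the first step that changes a single place, and it gives the first direct reading of this position, which compound 2 could not provide. On this ring carbon, one more heavy atom and one hydrogen-bond acceptor can enter without moving the number beyond the scatter. No measurement here bears on the reason for this result.

The compounds shown leave open whether a group such as ethoxy, an amine or a carboxylic acid on this ring carbon would also stay within the scatter, so a single exchange sets no limit on what the position accepts. They also leave open whether methoxy in place of methyl on the other ring carbons that bear a methyl group would give a similar step in this assay or a step beyond the scatter.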